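Methyl Added to a Branched Chain: Expected Blood-Pressure Dose Shift

This account rests on a few compounds, and the source may have more. Where it says the series, first, only, none or still open, it means among the compounds named here.

Compound 1, `CCCC(C)(C)/N=C(\NC#N)Nc1cccnc1`: 1 mg/kg
Compound 2, `CC(C)CC(C)(C)/N=C(\NC#N)Nc1cccnc1`: 2.5 mg/kg
Compound 3, `CCC(/N=C(\NC#N)Nc1ccncc1)C(C)C`: 5 mg/kg

All three were measured in a functional assay on the whole organism (blood, strain Wistar-Okamoto) with Rattus norvegicus as the target, with a stated time of 5 days; on this read-out higher numbers stand for an effect only at larger amounts of compound and lower numbers for an effect already at smaller amounts. Compound 2 differs from compound 1 by methyl in place of hydrogen on a saturated chain carbon bound to two saturated chain carbons, and that change gave a 2.5-fold higher number from compound 1 to compound 2 (0.40 log units; beyond the scatter). Compound 3 has the same atoms as compound 1 joined differently; the difference between the two cores is not broken down here. Its value and that of compound 2 lie within the usual scatter of each other.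

Compound 4, `CC(C)C(/N=C(\NC#N)Nc1ccncc1)C(C)C`, is not yet measured. It differs from compound 3 by methyl in place of hydrogen on a saturated chain carbon bound to two saturated chain carbons, the same change at the same kind of place as before. The expectation for it rests on the earlier step, a 2.5-fold higher number from compound 1 to compound 2 (0.40 log units; beyond the scatter). Compound 4 is therefore expected to show a 2.0-fold higher number from compound 3 to compound 4 (0.30 log units; within the scatter) in this assay . Compound 4 is estimated at 10 mg/kg, likely between 4 mg/kg and 30 mg/kg.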

Compound 4, minimum effective dose: 8 mg/kg
For compound 4 the middle estimate is 1.3-fold (0.10 log units) above the measured one; low and high end bracket the measured number.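

In this assay, methyl in place of hydrogen on a saturated chain carbon bound to two saturated chain carbons gave a 1.6-fold higher number from compound 3 to compound 4 (0.20 log units; within the scatter). Set beside the earlier step, the change reads alike on both cores, with no real difference between them: the same change on two cores in this assay, a 2.5-fold higher number (0.40 log units; beyond the scatter) from compound 1 to compound 2 and a 1.6-fold higher number (0.20 log units; within the scatter) from compound 3 to compound 4, 1.6-fold (0.19 log units) apart, within the scatter of two such steps This supports carrying the change from one of these cores to the other, but each core offers only one pair, and the new step on its own is too small to show a real shift, so no general rule follows.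

The compounds shown leave open how a longer chain, such as butyl, would read at this place. They also do not show what a polar group such as an amine would do there.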